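From thiophen-3-yl to 1-benzofuran-2-yl on a shared core

The source may hold more compounds than are shown below. What is called first, only, known or untested is meant among the compounds shown, and "the series" means these compounds.

Compound 1 `COc1ncnc2c1c(-c1cc3ccccc3o1)cn2[C@@H]1O[C@H](CO)[C@@H](O)[C@H]1O`, compound 2 `CNc1ncnc2c1c(-c1ccco1)cn2[C@@H]1O[C@H](CO)[C@@H](O)[C@H]1O` and compound 3 `CNc1ncnc2c1c(-c1ccsc1)cn2[C@@H]1O[C@H](CO)[C@@H](O)[C@H]1O` were tested in a functional assay on A549 cells (Homo sapiens), read by MTT assay, with a stated time of 72 h; on this read-out lower numbers stand for stronger inhibition and higher numbers for weaker inhibition. There, compound 1 gives 17700 nM and compound 2 gives 2570 nM. Compound 3 gives > 20000 nM, which is a limit of the assay and not a number. Compound 4 `CNc1ncnc2c1c(-c1cc3ccccc3o1)cn2[C@@H]1O[C@H](CO)[C@@H](O)[C@H]1O` differs from compound 3 in one place, an aromatic carbon: 1-benzofuran-2-yl in place of thiophen-3-yl on an aromatic carbon. Within the data shown here, the only measured step at this place is an at least 7.7-fold higher number from compound 2 to compound 3 (0.89 log units; beyond the scatter), where thiophen-3-yl replaced furan-2-yl. Read in reverse, that step suggests that leaving thiophen-3-yl for a ring with oxygen may bring the number down. Compound 1 calls for caution: it carries the same 1-benzofuran-2-yl group on a core that is not identical, and it gives 17700 nM. A moderate gain is therefore expected in this assay, with an estimated step of an at least 2.5-fold lower number from compound 3 to compound 4 (0.39 log units; beyond the scatter). For compound 4 the estimated value is 8000 nM, with an expected range of 2000 nM to 20000 nM.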

Compound 4, half-maximal inhibitory concentration: > 20000 nM
Compound 4 ended at the assay's limit; the forecaster's own chance of this, stated with the estimate: 20%; at least 2.5-fold (0.39 log units) between middle value and limit.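

The step from compound 3 to compound 4 cannot be read, because both compounds end at a limit of the assay and not at a number: the limit of > 20000 nM in this assay, at which 2 of the 4 values shown sit. What the result does show in this assay is that a ring oxygen at this place is not enough on the methylamino core: 1-benzofuran-2-yl in place of furan-2-yl gives an at least 7.7-fold higher number from compound 2 to compound 4 (0.89 log units; beyond the scatter), so the added six-membered aromatic ring does not keep the measurable activity of furan-2-yl. Methylamino in place of methoxy gives an at least 1.1-fold higher number from compound 1 to compound 4 (0.05 log units; that floor lies within the scatter), so this change shows no clear effect with 1-benzofuran-2-yl in place.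

The compounds shown leave open what furan-3-yl or a phenyl ring would give at this carbon. They also leave open whether a methyl group or a chlorine atom added to furan-2-yl would keep its activity.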